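Swapping the cinnamamide aryl group in a quinazoline cytotoxicity series

This account rests on a few compounds, and the source may have more. Where it says the series, first, only, none or still open, it means among the compounds named here.

Measured compounds:
- compound 1, `COc1ccc(/C=C/C(=O)Nc2cc3c(Nc4ccc(F)c(Cl)c4)ncnc3cc2O[C@H]2CCOC2)c(OC)c1`: 26500 nM
- compound 2, `COc1ccc(/C=C/C(=O)Nc2cc3c(Nc4ccc(F)c(Cl)c4)ncnc3cc2OC)cc1`: "not determined" (no result reported)
- compound 3, `COc1ccc(/C=C/C(=O)Nc2cc3c(Nc4ccc(F)c(Cl)c4)ncnc3cc2OC)c(OC)c1`: "not determined" (no result reported)

Three compounds share a core and differ in the substituent on the cinnamamide chain and in the ether group. In a functional assay on HeLa cells (Homo sapiens) for cytotoxicity, read by MTT assay, with a stated time of 72 h (on this read-out lower numbers stand for stronger inhibition and higher numbers for weaker inhibition), compound 1 gives 26500 nM, which marks weak cytotoxicity; it is the only numerical result available, as compound 2 gives "not determined" (no result reported) and compound 3 gives "not determined" (no result reported) in this assay. Within the data shown here, no step between two measured compounds can therefore be drawn.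

Compound 4, `O=C(/C=C/c1ccc(Br)cc1)Nc1cc2c(Nc3ccc(F)c(Cl)c3)ncnc2cc1O[C@H]1CCOC1`, keeps the core and ether of compound 1 and changes only the aryl group on the chain: 4-bromophenyl in place of 2,4-dimethoxyphenyl on a double-bonded chain carbon bound to a double-bonded chain carbon. With no measured neighbour to anchor the change, the expectation rests solely on compound 1. The step from compound 1 to compound 4 is expected to stay within the usual scatter or to reach at most a modest gain in cytotoxicity, and the expected step is a 1.5-fold lower number from compound 1 to compound 4 (0.17 log units; within the scatter). Compound 4 is thus estimated at 18000 nM in this assay, with a range from 6000 nM to 55000 nM, reflecting the absence of any comparator beyond compound 1 and its value of 26500 nM.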

Compound 4, half-maximal inhibitory concentration: 27500 nM
Compound 4: the middle estimate sits 1.5-fold (0.18 log units) below what was measured, and the stated range covers the measured number.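

In this assay, placing 4-bromophenyl in place of 2,4-dimethoxyphenyl on a double-bonded chain carbon bound to a double-bonded chain carbon gives a 1.0-fold higher number from compound 1 to compound 4 (0.02 log units; within the scatter), so this read-out does not separate the two compounds. Among these compounds, this is the first readable step at this position, and it shows that an aryl group carrying bromine and no oxygen and one carrying two methoxy groups remain within the scatter of each other, a statement that holds for this single pair only. Nothing available explains why the two groups give such similar numbers.

The compounds shown leave open whether any other group at this position would move the number beyond the scatter, such as a phenyl ring bearing a dimethylamino group or a carboxylic acid, or a pyridine ring in place of the phenyl ring. They also leave open whether the same exchange would give a similar step with a methoxy group in place of the cyclic ether on the shared core, since no step can be read for the methoxy compounds shown.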